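The source may report more compounds than this note shows. Statements on the series, on what has been measured and on what is new or still open speak of the compounds shown alone.

Compound 1, `Cc1ccc2nc(Nc3nc4ccc(F)cc4s3)sc2c1`, gives 29600 nM in a functional assay on B16-F10 cells (Mus musculus) for cytotoxicity, read by MTT assay, with a stated time of 48 h; on this read-out lower numbers stand for stronger inhibition and higher numbers for weaker inhibition.
Compound 2, `S=C(Nc1ccccc1)Nc1nc2c(Cl)cccc2s1`, gives > 50000 nM in this assay; this is a limit of the assay, not a number.

Within the data shown here, compound 2 therefore stands at the less active end of what was measured: its value is the one that sits at the limit of > 50000 nM in this assay, at which 1 of the 2 values shown sits, and compound 1 is the only compound with a measured number. The unmeasured compound 3, `S=C(Nc1ccccc1)Nc1nc2ccccc2s1`, differs from compound 2 in one place: hydrogen in place of chloro on an aromatic carbon. Among the measured compounds shown here, no pair of measured compounds differs in just one place, so the size of such a step in this assay is unknown from these data; a small change of this kind is expected to move the value little, likely not beyond the usual scatter, in either direction. For compound 3 an estimate of 60000 nM is expected, with a range from 15000 nM to 200000 nM. This means an expected step that the limit leaves unreadable from compound 2 to compound 3 in this assay.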

Compound 3, half-maximal inhibitory concentration: > 50000 nM
Compound 3: a limit, no number; the forecaster's own chance of this, stated with the estimate: 70%; the middle value is on the limit's open side.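

Compound 2 and compound 3 both give only a limit, not a number, in this assay, so no step can be read between them: the limit of > 50000 nM in this assay, at which 2 of the 3 values shown sit.

The compounds shown leave open whether hydrogen in place of chloro on an aromatic carbon changes the value at all.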